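The compounds below may be only part of what the source reports. "The series", "measured", "known", "first", "only" and "open" are said of these compounds alone.

Within the data shown here, compound 2, `NCC(N)CCCCNC(=O)CCn1cccc(O)c1=O`, is one of two compounds measured so far in a physicochemical assay, read by spectrophotometry, with a stated time of 10 min, tested at 200 uM, in the presence of a further agent that is not named here (on this read-out lower numbers stand for a weaker effect and higher numbers for a stronger effect at the one concentration tested), where compound 2 gives 62.8%. Among the measured compounds shown here, its only measured neighbour is compound 1, `NCC(N)CCCNC(=O)CCn1cccc(O)c1=O`, which in this assay gives 60%; the step of a number 2.8 percentage points higher from compound 1 to compound 2 (within the scatter) lies within the scatter, so compound 2 stands alongside compound 1 rather than apart from it.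

Compound 3, `NCC(N)CCCCNC(=O)CCn1cccc(OCc2ccccc2)c1=O`, differs from compound 2 in a different part of the molecule: benzyl in place of hydrogen on an oxygen on an aromatic ring. Cut one bond further out, the change reads hydroxy to benzyloxy.

For the measured compounds named here, none of the measured steps touches the oxygen on the aromatic ring; the single step known, from compound 1 to compound 2, alters the saturated chain three bonds from the amide-type nitrogen and was within the scatter. Going by the values given here, no measured step therefore bears on the change to compound 3, and the expectation for this assay rests on no precedent. The step from compound 2 to compound 3 is estimated as a number 37.8 percentage points lower from compound 2 to compound 3 (beyond the scatter), a drop beyond the scatter but with wide uncertainty. Compound 3 is accordingly expected to give about 25% in this assay, within a range from 5% to 55%.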

Compound 3, a percentage reported as activity, at one concentration (the size of the read-out at that concentration, not a potency): 33.9%
Beside the measured number, compound 3's estimate is 8.9 percentage points below it, and the stated range covers the measured number.
By their numbers in this assay, from the lowest: compound 3; then compounds 1 and 2 (each within the scatter of the next).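

Among these compounds, the oxygen on the aromatic ring is the first place where a change moves the read-out of this assay beyond the scatter: replacing the hydroxy with benzyloxy gives a number 28.9 percentage points lower from compound 2 to compound 3 (beyond the scatter) while the only earlier step, made in the saturated chain, was a number 2.8 percentage points higher from compound 1 to compound 2 (within the scatter) and left the numbers together. The hydrogen on this oxygen is nevertheless not required for all of the read-out, since compound 3, which carries benzyl there with its seven carbon atoms and no hydrogen-bond donors, keeps a measurable value (33.9%). No available evidence bears on what lies behind this drop.

From the compounds shown here alone, whether the size of the step belongs to the benzyl group in particular or to any replacement of that hydrogen stays open, as a methyl group on the same oxygen, or a longer chain ending in the phenyl ring, would be needed to separate the two. Going by these compounds, it is also open whether benzyl on the oxygen would lower the number to a similar extent on the shorter-chain compound 1.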